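Chloro for Fluoro in a Small Inhibition Set

The source may report more compounds than this note shows. Statements on the series, on what has been measured and on what is new or still open speak of the compounds shown alone.

Measured compounds:
compound 1 `Fc1ccc(-c2csc(N/N=C/c3ccccc3)n2)cc1`: 40%
compound 2 `Clc1ccc(-c2csc(N/N=C/c3ccccc3)n2)cc1`: 40%
compound 3 `COc1ccc(/C=N/Nc2nc(-c3ccc(F)cc3)cs2)cc1`: 40%

All three were tested in an in vitro assay on BTI-TN-5B1-4 cells for inhibition of Amine oxidase [flavin-containing] A (Homo sapiens), read by fluorescence, with a stated time of 15 min, tested at 100 uM; on this read-out higher numbers stand for more inhibition at the one concentration tested (going by the name of the read-out) and lower numbers for less inhibition. Compound 2 differs from compound 1 by chloro in place of fluoro on an aromatic carbon, and on this read-out no change at the digits printed from compound 1 to compound 2 (within the scatter). Compound 3 differs from compound 1 by methoxy in place of hydrogen on an aromatic carbon, and here too no change at the digits printed from compound 1 to compound 3 (within the scatter). Compound 3 therefore sits level with compound 1 and compound 2, and no order among the three can be claimed.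

Compound 4 `COc1ccc(/C=N/Nc2nc(-c3ccc(Cl)cc3)cs2)cc1` has not yet been measured. It differs from compound 3 by chloro in place of fluoro on an aromatic carbon, the same change as that from compound 1 to compound 2, at a place described in the same words, but on the core of compound 3 rather than that of compound 1. Because no change at the digits printed from compound 1 to compound 2 (within the scatter), the expected step is no change at the digits printed from compound 3 to compound 4 (within the scatter). Compound 4 is accordingly estimated at 40%, with a range from 25% to 55%.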

Compound 4, a percentage reported as inhibition, at one concentration (the size of the read-out at that concentration, not a potency): 40%
For compound 4 middle estimate and measured number coincide at the digits printed; low and high end bracket the measured number.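

In this assay, chloro in place of fluoro on an aromatic carbon gave no change at the digits printed from compound 3 to compound 4 (within the scatter), which matches the earlier step on the core of compound 1: the same change on two cores in this assay, no change at the digits printed (within the scatter) from compound 1 to compound 2 and no change at the digits printed (within the scatter) from compound 3 to compound 4, 0 percentage points apart, within the scatter of two such steps

Methoxy in place of hydrogen on an aromatic carbon gave no change at the digits printed from compound 2 to compound 4 (within the scatter), and this too matches its earlier counterpart: the same change on two cores in this assay, no change at the digits printed (within the scatter) from compound 1 to compound 3 and no change at the digits printed (within the scatter) from compound 2 to compound 4, 0 percentage points apart, within the scatter of two such steps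

Among these compounds, both changes therefore read the same on either core, but neither produced a step beyond the scatter, so this shows only that two null steps agree at one concentration, not that a real effect would carry across cores.

The compounds shown leave open whether an amine or a carboxylic acid in place of the methoxy would move this read-out. They also leave open how the four compounds would compare in a potency measurement.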